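A Diethylamino Swap on a Silent Pair

This account rests on a few compounds, and the source may have more. Where it says the series, first, only, none or still open, it means among the compounds named here.

In a functional assay on MCF7 cells (Homo sapiens) for antiproliferative activity, read by CCK-8 assay, with a stated time of 24 h (a higher number here means a weaker inhibitor, a lower number a stronger inhibitor), compound 1 `CN(C)Cc1ccc2nc(NC(=O)N/N=C/c3ccccn3)sc2c1` gives > 40000 nM as a limit of the assay, not a number. In this assay compound 2 `C/C(=N\NC(=O)Nc1nc2ccc(CN(C)C)cc2s1)c1ccccn1` gives > 40000 nM as a limit too. Compound 1 thus stands at the limit of > 40000 nM in this assay, at which 2 of the 2 values shown sit, and has no measured number. Compound 3 `CCN(CC)Cc1ccc2nc(NC(=O)N/N=C/c3ccccn3)sc2c1` carries diethylamino in place of dimethylamino on a saturated chain carbon bound to an aromatic carbon. Within the data shown here, no measured step shows what this change does, so the expected a number no higher from compound 1 to compound 3 (the limit leaves the size open) is no shift beyond the scatter, in either direction. Compound 3 is estimated at 40000 nM with an expected range from 20000 nM to 80000 nM and may well return only a limit.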

Compound 3, half-maximal inhibitory concentration: > 40000 nM
Compound 3: only a limit was reported; the forecaster's own chance of this, stated with the estimate: 75%; the middle value lies on the limit itself.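

No step can be read from compound 1 to compound 3, for both results in this assay are limits and not numbers: the limit of > 40000 nM in this assay, at which 3 of the 3 values shown sit.

The compounds shown leave open whether diethylamino in place of dimethylamino changes antiproliferative activity at all.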